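Ethoxy in place of cyano: expected shift for compound 4

The source may report more compounds than this note shows. Statements on the series, on what has been measured and on what is new or still open speak of the compounds shown alone.

Measured so far in a functional assay on HEK293 cells for agonist activity at Neuronal acetylcholine receptor; alpha3/beta4 (Homo sapiens), read by FLIPR; a higher number here means that more compound is needed for the effect, a lower number that less compound is needed: compound 1 `c1cncc(N2CC[C@H]3CN[C@H]3C2)c1` gives 48 nM; compound 2 `N#Cc1cncc(N2CC[C@H]3CN[C@H]3C2)c1` gives 1000 nM; compound 3 `N#Cc1cncc(N2CC[C@@H]3CN[C@@H]3C2)c1` gives 490 nM.

Compound 2 stands at the highest of the three numbers. The nearest number belongs to its mirror image, a 2.0-fold lower number from compound 2 to compound 3 (0.31 log units; beyond the scatter), a step that rests only on (the fact that compounds 2 and 3 differ only in the configuration as drawn). The furthest is a 21-fold higher number from compound 1 to compound 2 (1.32 log units; beyond the scatter), a large step.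

Compound 4 `CCOc1cncc(N2CC[C@H]3CN[C@H]3C2)c1` differs from compound 2 by ethoxy in place of cyano on an aromatic carbon. Within the data shown here, of the measured steps only a 21-fold higher number from compound 1 to compound 2 (1.32 log units; beyond the scatter) changes the same aromatic carbon, and it was large; no measured step exchanges cyano for ethoxy, so the size for ethoxy is open. With compound 1 at 48 nM and compound 2 at 1000 nM, the number for compound 4 is expected to fall between the two. Compound 4 is therefore estimated at 300 nM, in the range 60 nM to 1500 nM, an expected 3.3-fold lower number from compound 2 to compound 4 (0.52 log units; beyond the scatter).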

Compound 4, half-maximal effective concentration: 124 nM
Compound 4: the middle estimate sits 2.4-fold (0.38 log units) above what was measured; the range from low to high includes it.
By their numbers in this assay, from the lowest: compound 1; then compound 4; then compound 3; then compound 2.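

In this assay the outcome at this aromatic carbon depends on the group that enters, not merely on the hydrogen being replaced: exchanging cyano for ethoxy gives an 8.1-fold lower number from compound 2 to compound 4 (0.91 log units; beyond the scatter). Ethoxy does not fully close the gap to the core without a substituent, with a 2.6-fold higher number from compound 1 to compound 4 (0.41 log units; beyond the scatter). Nothing on hand accounts for the difference between cyano and ethoxy.

Open, going by these compounds, is whether methoxy, a longer propoxy chain or an amine on this carbon would come closer to compound 1. Also open, on these data alone, is whether ethoxy would give a similar step on the mirror-image core of compound 3.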